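A few compounds are considered here, and "the series" means these few. Any claim that something is new, unique, unknown or untested is made for them only; others in the source may bear on it.

Measured in a functional assay on HCT-116 cells (Homo sapiens) for cytotoxicity, read by sulforhodamine B assay, with a stated time of 48 h; a lower number here means a stronger inhibitor, a higher number a weaker inhibitor:
- compound 1 (`COc1cccc(/C=C/C(=O)/C=C/c2ccc(OCc3cn(CCOc4cc(=O)oc5ccccc45)nn3)c(OC)c2)c1`), value (9760 nM)
- compound 2 (`COc1cc(/C=C/C(=O)/C=C/c2ccco2)ccc1OCc1cn(CCOc2cc(=O)oc3ccccc23)nn1`), value (9180 nM)

Compound 2 stands at (9180 nM) and lies within the scatter of compound 1, so the two cannot be ranked. Next in the series is compound 3 (`COc1ccc(/C=C/C(=O)/C=C/c2ccc(OCc3cn(CCOc4cc(=O)oc5ccccc45)nn3)c(OC)c2)cc1`), which differs from compound 2 by one change (4-methoxyphenyl in place of furan-2-yl on a double-bonded chain carbon bound to a double-bonded chain carbon). In words, this is 4-methoxyphenyl in place of furan-2-yl on a double-bonded chain carbon bound to a double-bonded chain carbon.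

Among the compounds with values here, one measured step bears on this place, a 1.1-fold lower number from compound 1 to compound 2 (0.03 log units; within the scatter) and it exchanged 3-methoxyphenyl for furan-2-yl without leaving the scatter. Within the data shown here, with only that step to go on, no shift beyond the scatter is expected in this assay on returning to a methoxyphenyl group. Among the measured compounds shown here, no measured pair compares 4-methoxyphenyl with 3-methoxyphenyl, so the range is kept wide. The expected change is a 1.0-fold higher number from compound 2 to compound 3 (0.01 log units; within the scatter) and it is not expected to exceed the scatter. For compound 3 the estimated value is 9300 nM with an expected range from 4500 nM to 18000 nM in this read-out.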

Compound 3, half-maximal inhibitory concentration: 9290 nM
For compound 3 the middle estimate is 1.0-fold (0.00 log units) above the measured one, within the range that was stated.
By their numbers in this assay, from the lowest: compounds 2, 3 and 1 (each within the scatter of the next).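

In this assay, within the data shown here, the exchange of furan-2-yl for 4-methoxyphenyl gives a 1.0-fold higher number from compound 2 to compound 3 (0.01 log units; within the scatter) and the first direct comparison of the two methoxyphenyl groups gives a 1.1-fold lower number from compound 1 to compound 3 (0.02 log units; within the scatter) on the same double-bonded chain carbon bound to a double-bonded chain carbon. All three pairs at this place now lie within the scatter, so furan-2-yl, 3-methoxyphenyl and 4-methoxyphenyl cannot be ranked, although the set spans a five-membered aromatic ring with 1 hetero atom and six-membered aromatic rings of carbon only, and the methoxy group appears in two placements. No accompanying data speak to why the read-out stays flat across these groups.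

Every group shown at this place is an aromatic ring, so it remains open whether a cyclohexyl ring in its stead, or an amine or a carboxylic acid on the phenyl ring, would move the number beyond the scatter. These steps also leave the rest of the shared core untouched, so the effect of changes elsewhere in the molecule is open too.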